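Where Compound 2 Stands and What Compound 4 May Do

This account rests on a few compounds, and the source may have more. Where it says the series, first, only, none or still open, it means among the compounds named here.

Compound 1 `CC(=O)O[C@]1(C)/C=C/C(=O)/C(CO)=C\C[C@](C)(CCC=C(C)C)/C=C/[C@H]1OC(=O)C=C(C)C` gives 2320 nM
Compound 2 `CC(C)=CCC[C@]1(C)/C=C/[C@@H](OC(=O)C=C(C)C)[C@](C)(O)/C=C/C(=O)/C(CN(C)C)=C\C1` gives 690 nM
Compound 3 `CC(C)=CCC[C@]1(C)/C=C/[C@@H](OC(=O)C=C(C)C)[C@](C)(O)CCC(=O)/C(CO)=C\C1` gives > 40000 nM (a limit)

In a functional assay on MCF7 cells (Homo sapiens) for antiproliferative activity, read by MTT assay, with a stated time of 48 h (a higher number here means a weaker inhibitor, a lower number a stronger inhibitor), compound 2 has the lowest number shown (690 nM), and the nearest, beyond the scatter, is compound 1 (2320 nM). Compound 3 reaches only a limit of the assay (> 40000 nM). Compound 4 `CC(C)=CCC[C@]1(C)/C=C/[C@@H](OC(=O)C=C(C)C)[C@](C)(O)/C=C/C(=O)/C(COC(=O)c2ccc([N+](=O)[O-])cc2)=C\C1` has not yet been measured. It departs from compound 2 by ((4-nitrophenyl)carbonyl)oxy in place of dimethylamino on a saturated chain carbon bound to a double-bonded ring carbon with ((4-nitrophenyl)carbonyl)oxy in place of dimethylamino on a saturated chain carbon bound to a double-bonded ring carbon. Going by the values given here, no measured step covers this change, so the expectation rests only on the values of compound 2 (690 nM) and compound 1 (2320 nM). A moderate rise beyond the scatter is expected in this assay. The estimated change is a 2.9-fold higher number from compound 2 to compound 4 (0.46 log units; beyond the scatter) (towards a weaker inhibitor). Compound 4 is expected at 2000 nM (estimated range 500 nM to 9000 nM).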

Compound 4, half-maximal inhibitory concentration: 670 nM
For compound 4 the middle estimate is 3.0-fold (0.47 log units) above the measured one; the range from low to high includes it.
By their numbers in this assay, from the lowest: compounds 4 and 2 (each within the scatter of the next); then compound 1. At a limit, above all of these: compound 3.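

In this assay, ((4-nitrophenyl)carbonyl)oxy in place of dimethylamino on a saturated chain carbon bound to a double-bonded ring carbon gives a 1.0-fold lower number from compound 2 to compound 4 (0.01 log units; within the scatter). The value of compound 2 therefore does not depend on an amine at this place, and a much larger group carrying a six-membered aromatic ring leaves the number within the scatter. Nothing shown gives a reason for this result. Open remains whether the nitro group on the ring matters, and what an unsubstituted benzoyloxy group, a carboxylic acid or a longer amine chain would give at this place.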